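Benzyl for butylcarbamoyl on the hydroxypropyl arm

The source may hold more compounds than are shown below. What is called first, only, known or untested is meant among the compounds shown, and "the series" means these compounds.

Three compounds of the series have numbers in an assay on nucleic acid for inhibition of Nucleic Acid, read by fluorescence, tested at 100 uM; a lower number here means less inhibition, a higher number more inhibition at the concentration tested (going by the name of the read-out). Compound 1 `CCCCN(CCCC)Cc1cn(CC(O)COCc2ccccc2)nn1` gives 6% in this assay. Compound 2 `CCCCNC(=O)OCC(O)Cn1cc(CN2CCCC(C(=O)OCC)C2)nn1` gives 24%, and compound 3 `CN(Cc1cn(C2CCCCC2OC(=O)COc2ccccc2)nn1)CC1CCCCC1` gives 37%. Compound 2 stands second of the three: compound 3 sits higher by a margin beyond the scatter, and compound 1 sits lower, also beyond the scatter.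

Compound 4 `CCOC(=O)C1CCCN(Cc2cn(CC(O)COCc3ccccc3)nn2)C1` is not yet measured. It differs from compound 2 in one place: benzyl in place of butylcarbamoyl on an oxygen on a saturated carbon. For the measured compounds named here, no pair of measured compounds differs in exactly this way, so the size of the step has no direct precedent. Compound 1 also carries a (benzyloxy)methyl and gives the lowest of the three numbers, which points to a drop rather than a gain for compound 4, though compound 1 differs from compound 4 in other places as well.

For compound 4 in this assay a value of 14% is expected, with a range from 3% to 30%. The estimated step of a number 10 percentage points lower from compound 2 to compound 4 (within the scatter) is a modest loss of inhibition, expected to lie around the edge of the scatter.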

Compound 4, a percentage reported as inhibition, at one concentration (the size of the read-out at that concentration, not a potency): 26%
Estimate against measurement, compound 4: 12 percentage points below; low and high end bracket the measured number.
By their numbers in this assay, from the lowest: compound 1; then compounds 2 and 4 (each within the scatter of the next); then compound 3.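

In this assay, for the compounds shown here, benzyl in place of butylcarbamoyl on an oxygen on a saturated carbon gives a number 2 percentage points higher from compound 2 to compound 4 (within the scatter), the first step that can be read at a single place. The hydrogen-bond donor and acceptor of butylcarbamoyl are gone and a six-membered aromatic ring of carbon only has entered, yet the numbers of the pair stay within the scatter of each other, so with this amine part the position shows no dependence on that difference. No measurement at hand bears on why the pair reads alike.

From the compounds shown here alone, the step rests on one pair at one concentration, and whether it holds with other amine parts remains open. Phenyl or a longer chain such as octylcarbamoyl at this oxygen would show how far the position stays this flat.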